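The compounds below may be only part of what the source reports. "The series", "measured", "known", "first", "only" and "open" are said of these compounds alone.

Three amines on a shared core have been measured in a functional assay on the whole organism with Mus musculus as the target; a lower number here means that less compound is needed, a higher number that more compound is needed for the effect. In this assay, compound 1 (`Cc1cc(-c2ccccc2)nnc1NCCCN`) gives 50 mg/kg. Compound 2 (`Cc1cc(-c2ccccc2)nnc1NCCCCN`) reaches only a limit, > 50 mg/kg. Compound 3 (`CCN(CC)CCNc1nnc(-c2ccccc2)cc1C`) also reaches only a limit, > 30 mg/kg, and so has no exact standing among the three.

Compound 4 (`CCCN(CCC)CCNc1nnc(-c2ccccc2)cc1C`) differs from compound 3 on the side chain: dipropylamino in place of diethylamino on a saturated chain carbon, two bonds along the chain from a nitrogen on an aromatic ring. The measured steps give little guidance on size. They show a number no lower from compound 1 to compound 2 (the limit leaves the size open), then a step that the limit leaves unreadable from compound 1 to compound 3 and a step that the two limits leave unreadable from compound 2 to compound 3. None of them has a readable size, and none swaps dipropylamino for diethylamino.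

The expectation therefore rests on compound 3 and its limit of > 30 mg/kg. No step beyond the usual scatter is expected in this assay, and the estimated change is a step that the limit leaves unreadable from compound 3 to compound 4. For compound 4 the estimated value is 40 mg/kg, with an expected range from 15 mg/kg to 100 mg/kg, and the assay may well report only a limit again.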

Compound 4, dose for half-maximal effect: > 30 mg/kg
Compound 4 ended at the assay's limit; the forecaster's own chance of this, stated with the estimate: 60%; the middle value does not contradict the limit.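

In this assay compound 4 gives > 30 mg/kg, which is a limit, so its steps from compound 1, compound 2 and compound 3 cannot be read. The compounds shown leave open whether dipropylamino and diethylamino differ at all in this assay.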